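From a Drawn Configuration to an Undrawn One

This account rests on a few compounds, and the source may have more. Where it says the series, first, only, none or still open, it means among the compounds named here.

Compound 1 `OC(CCn1nc2c(Br)c(Br)c(Br)c(Br)c2n1)c1ccc(Br)cc1`: 58%
Compound 2 `OC(CCn1nc2c(Br)c(Br)c(Br)c(Br)c2n1)c1ccccc1`: 66%
Compound 3 `C[C@@H](O)CCn1nc2c(Br)c(Br)c(Br)c(Br)c2n1`: 69%

Of the compounds shown here, three sharing one core have been tested in a functional assay on CCRF-CEM cells (Homo sapiens) for antiproliferative activity, read by MTT assay, with a stated time of 24 h, tested at 50 uM; a higher number here means a weaker effect of the compound at the concentration tested, a lower number a stronger effect. Compound 3 stands highest of the three numbers. Its nearest neighbour is compound 2, whose number is lower but within the scatter, so that the two cannot be set in order. Its furthest neighbour is compound 1, whose number is lower by a gap that is beyond the scatter.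

Going by the values given here, only one pair of measured compounds differs in a single place: a number 8 percentage points higher from compound 1 to compound 2 (within the scatter). That change is a hydrogen in place of bromo on an aromatic carbon, and it concerns a substituent, not a stereocentre.

Compound 4 `CC(O)CCn1nc2c(Br)c(Br)c(Br)c(Br)c2n1` is not yet measured. It differs from compound 3 in this way: the two compounds have the same atoms and bonds; at least one stereo element is drawn with a configuration in one of them and without one in the other: 1 of 1 stereo elements differ; a stereocentre at a saturated chain carbon is drawn R in compound 3 and without a configuration in compound 4. No measured step touches a stereocentre alone, so none of the steps shown bears directly on this change; the only guidance is that compound 3 itself gives 69% in this assay, and compound 4 carries the same atoms and bonds. With nothing to indicate a direction, the step of a number 1 percentage points lower from compound 3 to compound 4 (within the scatter) is expected to lie within the scatter. Compound 4 is therefore estimated to give 68%, with a range from 55% to 80%.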

Compound 4, a percentage reported as activity, at one concentration (the size of the read-out at that concentration, not a potency): 89%
Beside the measured number, compound 4's estimate is 21 percentage points below it; the whole stated range lies below it.
By their numbers in this assay, from the lowest: compounds 1, 2 and 3 (each within the scatter of the next, the first and the last beyond it); then compound 4.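

In this assay, going by these compounds alone, how the stereocentre at the saturated chain carbon is drawn proves not to be a neutral detail, a point no earlier step could show, since none touched a stereocentre alone: the result is a number 20 percentage points higher from compound 3 to compound 4 (beyond the scatter). Replacing the aryl group on that carbon with methyl also gives a shift beyond the scatter, with a number 23 percentage points higher from compound 2 to compound 4 (beyond the scatter) for methyl in place of phenyl and a number 31 percentage points higher from compound 1 to compound 4 (beyond the scatter) for methyl in place of 4-bromophenyl, which leaves the undrawn methyl compound with the weakest effect of the four. The structures separate the two methyl compounds in one respect only: the fact that one of compounds 3 and 4 is drawn with a defined configuration and the other without, at the place where they differ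

The compounds shown do not tell whether the undrawn stereocentre stands for a single configuration or a mixture, so they leave open how the opposite configuration alone would read in this assay. They also leave open how the number would move with a longer chain or an amine in place of the methyl on that carbon.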